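The source may report more compounds than this note shows. Statements on the series, on what has been measured and on what is new or still open speak of the compounds shown alone.

- compound 1 `CCCOc1c(-c2cc(OC)c(OC)c(OC)c2)oc2ccccc2c1=O`: 5700 nM
- compound 2 `CCCCOc1c(-c2cc(OC)c(OC)c(OC)c2)oc2ccccc2c1=O`: 8900 nM

In a functional assay on LNCaP cells (Homo sapiens) for antiproliferative activity, read by WST assay, with a stated time of 3 days (a lower number here means a stronger inhibitor, a higher number a weaker inhibitor), compound 2 gives 8900 nM, within the scatter of compound 1, so the two cannot be told apart. Compound 3 `CCCCCCOc1c(-c2cc(OC)c(OC)c(OC)c2)oc2ccccc2c1=O` extends the chain of compound 2: ethyl in place of hydrogen on a saturated chain carbon, four bonds along the chain from an oxygen on an aromatic ring. Among the compounds with values here, only one measured step bears on this change. It shows a 1.6-fold higher number from compound 1 to compound 2 (0.19 log units; within the scatter), a step that lengthens the same chain. That single step gives only a weak guide, and the new change is larger. A small move toward a higher number is therefore expected, not clearly beyond the scatter. The expected move is a 1.5-fold higher number from compound 2 to compound 3 (0.16 log units; within the scatter). For compound 3 the estimated value is 13000 nM, with an expected range from 5500 nM to 30000 nM.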

Compound 3, half-maximal inhibitory concentration: 19600 nM
Compound 3: middle estimate off by 1.5-fold (0.18 log units), on the low side; measured number inside the range.
By their numbers in this assay, from the lowest: compounds 1 and 2 (each within the scatter of the next); then compound 3.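

In this assay, lengthening the chain on this oxygen now produces a step that can be told from the scatter (a 2.2-fold higher number from compound 2 to compound 3 (0.34 log units; beyond the scatter)), whereas the earlier step (a 1.6-fold higher number from compound 1 to compound 2 (0.19 log units; within the scatter)) could not. Read end to end, the same change gives a larger step (a 3.4-fold higher number from compound 1 to compound 3 (0.54 log units; beyond the scatter)), so compound 3, with steps to both other compounds printed as beyond the scatter, is the weakest of the three in this series. No measurement shown here accounts for this loss of activity.

From the compounds shown here alone, whether a still longer chain would carry the trend further, or a shorter one such as methyl or ethyl would reverse it, remains open. So does the effect of placing an amine or a carboxylic acid on this chain.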